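Compound 2 to compound 3: thiophen-3-yl on the carbonyl

The source may report more compounds than this note shows. Statements on the series, on what has been measured and on what is new or still open speak of the compounds shown alone.

In a physicochemical assay for solubility, at pH 7 (a lower number here means a less soluble compound, a higher number a more soluble compound), compound 1 (`CN1CCC(C(=O)N2Cc3c(NC(=O)c4ccc5ccccc5c4)n[nH]c3C2(C)C)CC1`) gives 219000 nM. Compound 2 (`CN1CCC(C(=O)N2Cc3c(NC(=O)c4cc(F)cc(F)c4)n[nH]c3C2(C)C)CC1`) gives > 225000 nM, which is a limit of the assay and not a number. Compound 2 therefore has no exact place on the numbers shown, and its standing is given only by the limit of > 225000 nM in this assay, at which 1 of the 2 values shown sits.

Compound 3 (`CN1CCC(C(=O)N2Cc3c(NC(=O)c4ccsc4)n[nH]c3C2(C)C)CC1`) carries thiophen-3-yl in place of 3,5-difluorophenyl on a carbonyl carbon.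

Going by the values given here, the only measured step at this carbonyl carbon is an at least 1.0-fold higher number from compound 1 to compound 2 (0.01 log units; that floor lies within the scatter), and its floor lies within the scatter. On these data alone, that step bounds the change on one side only, so its true size remains open. With compound 1 at 219000 nM and no measured step beyond the scatter, no shift beyond the scatter is expected in this assay, and a direction cannot be assigned. The expected step is a number no higher from compound 2 to compound 3 (the limit leaves the size open). A report of a limit alone is also quite possible. Compound 3 is estimated at 225000 nM, with an expected range from 150000 nM to 280000 nM.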

Compound 3, solubility: > 225000 nM
Compound 3: a limit, no number (the forecaster's own chance of this, stated with the estimate: 65%); the middle value lies on the limit itself.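

In this assay compound 3 gives > 225000 nM, which is a limit of the assay and not a number. Going by these compounds alone, the one readable new step is an at least 1.0-fold higher number from compound 1 to compound 3 (0.01 log units; that floor lies within the scatter), so replacing naphthalen-2-yl with thiophen-3-yl on this carbonyl carbon shows no change beyond the scatter, while the step between the two limits cannot be read. What is new is that a five-membered aromatic ring with one hetero atom now ends at the same limit as the six-membered 3,5-difluorophenyl ring, and the series at this position is increasingly defined by that limit rather than by numbers: the limit of > 225000 nM in this assay, at which 2 of the 3 values shown sit.

On these data alone, how far compound 2 and compound 3 lie past the limit, and whether they differ from each other, remains open. Also open, as far as these compounds go, is whether any other group on this carbonyl carbon, such as a carboxylic acid, an amine or a longer alkyl chain, would give a number that can be read and that differs from compound 1 beyond the scatter.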